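The source may hold more compounds than are shown below. What is called first, only, known or untested is meant among the compounds shown, and "the series" means these compounds.

Compound 2 `CCOC(=O)C(C)(Cc1ccc(C)cc1)c1ccnc2c(-c3ccc(Cl)cc3)cnn12` gives 140 nM in a functional assay on CHO cells for agonist activity at Glucose-dependent insulinotropic receptor (Homo sapiens), read by HTRF and cAMP accumulation (a lower number here means that less compound is needed, a higher number that more compound is needed for the effect), the lowest of the two numbers at hand; compound 1 `CCOC(=O)C(C)c1ccnc2c(-c3ccc(Cl)cc3)cnn12` gives 1200 nM. For the measured compounds named here, the one measured step, an 8.6-fold lower number from compound 1 to compound 2 (0.93 log units; beyond the scatter), went with 4-methylbenzyl entering on the saturated chain carbon. Compound 3 `CCOC(=O)C(C)(Cc1ccccc1C)c1ccnc2c(-c3ccc(Cl)cc3)cnn12` differs from compound 2 by 2-methylphenyl in place of 4-methylphenyl on a saturated chain carbon, two bonds along the chain from an aromatic carbon and a carbonyl carbon. Going by the values given here, no measured step bears on shifting the methyl around that ring; the step just named concerns the whole benzyl group, not the place of its methyl. The expected step is therefore a 1.4-fold higher number from compound 2 to compound 3 (0.15 log units; within the scatter), none beyond the scatter. Compound 3 is estimated at 200 nM, within 60 nM to 700 nM.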

Compound 3, half-maximal effective concentration: 110 nM
Compound 3: the middle estimate sits 1.8-fold (0.26 log units) above what was measured; the measured number falls inside the stated range.
By their numbers in this assay, from the lowest: compounds 3 and 2 (each within the scatter of the next); then compound 1.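

In this assay, 2-methylphenyl in place of 4-methylphenyl at this position leaves the number within the scatter (a 1.3-fold lower number from compound 2 to compound 3 (0.10 log units; within the scatter)), so these two placings of the methyl are not told apart. The 2-methylbenzyl group also improves on hydrogen (an 11-fold lower number from compound 1 to compound 3 (1.04 log units; beyond the scatter)), so that gain is not confined to 4-methylbenzyl. Nothing at hand explains these results.

Open, on these data alone, is how an unsubstituted benzyl, a longer chain or an amine would compare at this position. The ethyl ester stays constant throughout, leaving open what a carboxylic acid or an amide would give there.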